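A few compounds are considered here, and "the series" means these few. Any claim that something is new, unique, unknown or untested is made for them only; others in the source may bear on it.

Three members of the series have been measured in a physicochemical assay for lipophilicity; on this read-out higher numbers stand for higher lipophilicity and lower numbers for lower lipophilicity. Compound 1 `NC(=O)C1(NC(=O)[C@@H](CCCC(=O)O)NC(=O)[C@@H](CCCCNC(=O)/C=C/c2cccnc2)NC(=O)c2ccc(Nc3nc4ccccc4[nH]3)cc2)CCCCC1` gives 1.83, compound 2 `NC(=O)C1(NC(=O)[C@@H](CCCC(=O)O)NC(=O)[C@@H](CCCCNC(=O)/C=C/c2cccnc2)NC(=O)c2cccc(Nc3nc4ccccc4[nH]3)c2)CCCCC1` gives 2.12, and compound 3 `NC(=O)C1(NC(=O)[C@@H](CCCC(=O)O)NC(=O)[C@@H](CCCCNC(=O)/C=C/c2cccnc2)NC(=O)CCc2ccc(Nc3nc4ccccc4[nH]3)cc2)CCCCC1` gives 2.8. Compound 1 thus holds the lowest of the three numbers; its gap to compound 2 falls within the usual scatter, while its gap to compound 3 lies beyond it.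

Compound 4 `Cc1cccc2[nH]c(Nc3ccc(C(=O)N[C@H](CCCCNC(=O)/C=C/c4cccnc4)C(=O)N[C@H](CCCC(=O)O)C(=O)NC4(C(N)=O)CCCCC4)cc3)nc12` is the next member and has not yet been measured in this assay. It differs from compound 1 in one place: methyl in place of hydrogen on an aromatic carbon, on an aromatic carbon of a six-membered aromatic ring of carbon only, part of a fused or bridged system of two rings, ortho to a fused ring and meta to a fused ring. Going by the values given here, no pair of the measured compounds differs in exactly this way, so no measured step can be carried over. A methyl in place of hydrogen is a small addition with no hydrogen-bond donors, no acceptors and no charge; in this assay a modest rise is expected, of a size close to the scatter itself. The expected step reads a number 0.42 log units higher from compound 1 to compound 4 (beyond the scatter). For compound 4 the estimate is 2.25, within a range from 1.85 to 2.65.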

Compound 4, partition coefficient: 2.58
Beside the measured number, compound 4's estimate is 0.33 log units below it; the range from low to high includes it.
By their numbers in this assay, from the lowest: compounds 1 and 2 (each within the scatter of the next); then compounds 4 and 3 (each within the scatter of the next).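

Moving from 1H-benzimidazol-2-yl to 4-methyl-1H-benzimidazol-2-yl gives the series its first change in a single place, and in this assay the step reads a number 0.75 log units higher from compound 1 to compound 4 (beyond the scatter). A single methyl, with no hydrogen-bond donors or acceptors and no net charge, on this aromatic carbon, ortho to a fused ring and meta to a fused ring, is thus enough to shift the number beyond the scatter. Nothing measured alongside this pair accounts for the size of the step.

As far as these compounds go, it remains open whether this step belongs to the methyl itself or to this place, which an ethyl, a chlorine or an amine on the same carbon, or a methyl on another carbon of that ring, could separate. Also open, from the compounds shown here alone, is whether the same methyl added to compound 2 or compound 3 gives a step of similar size.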